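The compounds below may be only part of what the source reports. "The series", "measured", "known", "first", "only" and "open" are said of these compounds alone.

Compound 1 `Nc1cc(N)c2nc(-c3ccccc3)c(Oc3ccc(Cl)c(Cl)c3)nc2c1` was tested in a functional assay on MOLT-4 cells (Homo sapiens) for inhibition, read by sulforhodamine B assay, with a stated time of 48 h; on this read-out higher numbers stand for lower toxicity in this test and lower numbers for higher toxicity in this test. For compound 1 the result is a limit of the test rather than a measured number, < 100000 nM. Compound 2 `CCOC(=O)[C@H](CCC(=O)O)NC(=O)c1ccc(Sc2nc3cc(N)cc(N)c3nc2-c2ccccc2)cc1` was tested the same way, and for compound 2 the result is likewise a limit, < 100000 nM. Going by the values given here, both results therefore sit at the limit of < 100000 nM in this assay, at which 2 of the 2 values shown sit, so no step between two measured numbers can be read from the data.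

Compound 3 `Nc1cc(N)c2nc(-c3ccccc3)c(Oc3ccc(F)cc3)nc2c1` differs from compound 1 in one place: 4-fluorophenyl in place of 3,4-dichlorophenyl on an oxygen on an aromatic ring. Nothing measured here shows how this kind of change moves the result in this assay. The expectation for the step is therefore no shift beyond the usual scatter, a step that the limit leaves unreadable from compound 1 to compound 3. Compound 3 is expected to give about 50000 nM, within a range from 10000 nM to 100000 nM, and it may well again be reported only as a limit.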

Compound 3, concentration lethal to 50% of the cells: < 100000 nM
Compound 3: no number, only a limit; the forecaster's own chance of this, stated with the estimate: 50%; the middle value lies beyond the limit too.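

Compound 1 and compound 3 both give only a limit in this assay, not a measured number, so no step can be read between them: the limit of < 100000 nM in this assay, at which 3 of the 3 values shown sit.

The compounds shown leave open whether 4-fluorophenyl in place of 3,4-dichlorophenyl changes the result at all.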